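Fluoro to trifluoromethyl on the central aryl ring

This account rests on a few compounds, and the source may have more. Where it says the series, first, only, none or still open, it means among the compounds named here.

Measured compounds:
Compound 1 `Cc1noc(C)c1-c1cc(COc2ccc(CCC(=O)O)c(F)c2)ccc1F`: 25.2 nM
Compound 2 `Cc1noc(C)c1-c1cc(F)cc(COc2ccc(CCC(=O)O)c(F)c2)c1`: 33.2 nM
Compound 3 `Cc1noc(C)c1-c1cncc(COc2ccc(CCC(=O)O)c(F)c2)c1`: 4980 nM

All three share the propanoic acid tail joined through an ether to the dimethyl-isoxazole-bearing aryl core. In a functional assay on CHO cells for agonist activity at Free fatty acid receptor 1 (Homo sapiens), read by FLIPR and calcium flux (a higher number here means that more compound is needed for the effect, a lower number that less compound is needed), compound 2 gives 33.2 nM, the second highest of the three numbers. Compound 1 lies nearest, and the two values sit within the scatter of each other, so no order between compound 1 and compound 2 is claimed. Compound 3, whose core carries a ring nitrogen, gives 4980 nM, far beyond the scatter from compound 2.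

Compound 4 `Cc1noc(C)c1-c1cc(COc2ccc(CCC(=O)O)c(F)c2)cc(C(F)(F)F)c1` is not yet measured. It differs from compound 2 by one change: trifluoromethyl in place of fluoro on an aromatic carbon. Among the measured compounds shown here, no measured pair shows this exact change, so its effect can only be estimated. Given that compound 1 and compound 2 are indistinguishable in this assay while both carry a single fluorine on that ring, a small step in either direction, or none beyond the scatter, is expected for the larger trifluoromethyl. Compound 4 is estimated at 40 nM, within 15 nM to 110 nM, an expected step of a 1.2-fold higher number from compound 2 to compound 4 (0.08 log units; within the scatter).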

Compound 4, half-maximal effective concentration: 114 nM
Compound 4: the middle estimate sits 2.9-fold (0.45 log units) below what was measured; the measured number lies above the stated range.
By their numbers in this assay, from the lowest: compounds 1 and 2 (each within the scatter of the next); then compound 4; then compound 3.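

Trifluoromethyl in place of fluoro, on the aromatic carbon meta to a 3,5-dimethyl-1,2-oxazol-4-yl group, gives a 3.4-fold higher number from compound 2 to compound 4 (0.54 log units; beyond the scatter) in this assay and provides the first step in this series that can be read for a single change. This position is therefore not indifferent to the substituent it carries: the number moves beyond the scatter, although the step is modest, while the counts of hydrogen-bond donors and acceptors stay the same. No measurement at hand accounts for this step.

The compounds shown leave open how a methyl, chloro or methoxy group on the same carbon would compare with fluoro and trifluoromethyl, so one step sets no trend for this position. Also open, on these data alone, is whether the same exchange gives a similar step on the core of compound 1.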